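A few compounds are considered here, and "the series" means these few. Any claim that something is new, unique, unknown or untested is made for them only; others in the source may bear on it.

Measured compounds in an assay on CHO-K1 cells for antagonist activity at transient receptor potential cation channel subfamily V member 1 (Homo sapiens), read by FLIPR and calcium flux, with a stated time of 6 min; on this read-out higher numbers stand for weaker inhibition and lower numbers for stronger inhibition: compound 1 `Cn1ncc2c(NC(=O)NCc3cc(C(F)(F)F)nn3-c3ccc(Cl)cc3)cccc21` gives 2.7 nM; compound 2 `CC(C)(C)c1cc(CNC(=O)Nc2cccc3[nH]ncc23)n(-c2ccc(F)c(F)c2)n1` gives 0.5 nM; compound 3 `Cn1ncc2c(NC(=O)NCc3cc(C(C)(C)C)nn3-c3ccc(Cl)cc3)cccc21` gives 9.5 nM.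

Compound 3 stands highest of the three numbers, with compound 1 nearest and compound 2 furthest. Going by the values given here, the one single-place step measured is a 3.5-fold higher number from compound 1 to compound 3 (0.55 log units; beyond the scatter), and it concerns the tert-butyl, not the group on the aromatic nitrogen. Compound 4 `Cn1ncc2c(NC(=O)NCc3cc(C(C)(C)C)nn3-c3ccc(F)c(F)c3)cccc21` carries 3,4-difluorophenyl in place of 4-chlorophenyl on an aromatic nitrogen. Among the compounds with values here, no measured step covers this change. Compound 2 also bears a 3,4-difluorophenyl and gives a lower number than compound 3, but it differs from compound 3 in the core as well, so its value is only a loose pointer. Compound 4 is therefore estimated at 5 nM in this assay, with a range of 1.5 nM to 15 nM, an expected step of a 1.9-fold lower number from compound 3 to compound 4 (0.28 log units; within the scatter).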

Compound 4, inhibition constant: 1 nM
Compound 4: middle estimate off by 5.0-fold (0.70 log units), on the high side; the measured number lies below the stated range.
By their numbers in this assay, from the lowest: compounds 2 and 4 (each within the scatter of the next); then compound 1; then compound 3.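

In this assay 3,4-difluorophenyl in place of 4-chlorophenyl on the aromatic nitrogen gives a 9.5-fold lower number from compound 3 to compound 4 (0.98 log units; beyond the scatter) and shows that, with tert-butyl held constant, this position moves the number beyond the scatter. Methyl in place of hydrogen on an aromatic nitrogen gives a 2.0-fold higher number from compound 2 to compound 4 (0.30 log units; within the scatter) and so stays within the scatter with 3,4-difluorophenyl present. No available evidence explains either step. Still open, going by these compounds, is whether the 3,4-difluorophenyl step holds with trifluoromethyl in place of tert-butyl, and how a pyridine or a 4-methoxyphenyl on that nitrogen would read.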